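The source may hold more compounds than are shown below. What is called first, only, known or untested is meant among the compounds shown, and "the series" means these compounds.

Compound 1 `CC(C)c1ccc(OC(C)(Cc2ccccc2)C(=O)O)cc1`: > 10 mg/kg
Compound 2 `Cc1cccc(CC(C)(Oc2ccc(C(C)C)cc2)C(=O)O)c1`: < 1 mg/kg

In a functional assay on the whole organism for inhibition, with Rattus norvegicus as the target (on this read-out lower numbers stand for an effect already at smaller amounts and higher numbers for an effect only at larger amounts of compound), compound 2 gives < 1 mg/kg, which is a limit and not a number. Compound 1 gives > 10 mg/kg, which is also a limit, so neither of the two values shown is an exact figure.

Compound 3 `Cc1ccc(CC(C)(Oc2ccc(C(C)C)cc2)C(=O)O)cc1` has the same atoms as compound 2, joined differently: 4-methylphenyl in place of 3-methylphenyl on a saturated chain carbon, two bonds along the chain from a carbonyl carbon and an oxygen on an aromatic ring. It carries 4-methylphenyl in place of 3-methylphenyl on a saturated chain carbon, two bonds along the chain from a carbonyl carbon and an oxygen on an aromatic ring.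

Among the measured compounds shown here, only one measured step bears on this change: an at least 10-fold lower number from compound 1 to compound 2 (1.00 log units; beyond the scatter), with methyl in place of hydrogen on an aromatic carbon. That step lies beyond the scatter. For the measured compounds named here, compound 3 keeps a methyl on this group, but no measured step compares the two methylphenyl groups. Most of the gain is therefore expected to remain, with only a small loss possible. The expected change is a number no lower from compound 2 to compound 3 (the limit leaves the size open), an estimate that is uncertain in size and direction. For compound 3 the estimated value is 1 mg/kg, with an expected range from 0.2 mg/kg to 6 mg/kg.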

Compound 3, dose for half-maximal effect: < 1 mg/kg
Compound 3: only a limit was reported; the forecaster's own chance of this, stated with the estimate: 55%; the middle value sits exactly at the limit.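

In this assay compound 3 gives < 1 mg/kg, which is a limit and not a number. With 4-methylphenyl on the saturated chain carbon there is also an at least 10-fold lower number from compound 1 to compound 3 (1.00 log units; beyond the scatter), so the gain seen earlier is not tied to 3-methylphenyl alone. The step between 3-methylphenyl and 4-methylphenyl cannot be read, because compound 2 and compound 3 both stand at the same limit: the limit of < 1 mg/kg in this assay, at which 2 of the 3 values shown sit.

On these data alone, how far compound 2 and compound 3 lie past their shared limit remains open, so neither methylphenyl group can be placed ahead of the other. As far as these compounds go, it is also open whether 2-methylphenyl, or another group on the aromatic ring in place of methyl, such as chloro, methoxy or ethyl, would keep the gain over compound 1.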